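The source may hold more compounds than are shown below. What is called first, only, known or untested is meant among the compounds shown, and "the series" means these compounds.

Compound 1 `COc1cc(-c2nc(CO[C@@H]3O[C@H](CSc4ncn[nH]4)[C@H]4OC5(CCCC5)O[C@@H]34)no2)cc(OC)c1OC` — in a functional assay on HeLa cells (Homo sapiens) for antiproliferative activity, read by sulforhodamine B assay, with a stated time of 48 h (on this read-out higher numbers stand for weaker inhibition of growth and lower numbers for stronger inhibition of growth), compound 1 gives 37000 nM
Compound 2 `O=[N+]([O-])c1ccc(-c2nc(CO[C@@H]3O[C@H](CO)[C@H]4OC5(CCCC5)O[C@@H]34)no2)cc1` — in this assay compound 2 gives 15000 nM
Compound 3 `CC1(C)O[C@H]2[C@H](OCc3noc(-c4ccc([N+](=O)[O-])cc4)n3)O[C@H](CSc3ncn[nH]3)[C@H]2O1` — in this assay compound 3 gives 89000 nM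

On these three numbers compound 3 stands highest, meaning it is the weakest inhibitor of growth of the set. Its nearest neighbour is compound 1, and that gap lies beyond the usual scatter; the gap to compound 2 is wider still. No two of the measured compounds differ in only one place, so no single change can be read directly from them. Among the measured compounds shown here, what can be said is that the one compound carrying a hydroxy group at the chain end, compound 2, gives the lowest number, while the two compounds with the triazolylsulfanyl group there give the higher ones.

Compound 4 `CC1(C)O[C@H]2[C@H](OCc3noc(-c4ccc([N+](=O)[O-])cc4)n3)O[C@H](CO)[C@H]2O1` has not yet been measured. It differs from compound 3 in one place: hydroxy in place of (1H-1,2,4-triazol-5-yl)sulfanyl on a saturated chain carbon bound to a saturated ring carbon. Compound 4 thereby comes to share its hydroxymethyl chain and its nitrophenyl group with compound 2, only the core differing between them. For the measured compounds named here, with no measured one-step pair to lean on, the expectation leans on the fact that compound 2 gives 15000 nM in this assay. The step expected is a 3.0-fold lower number from compound 3 to compound 4 (0.47 log units; beyond the scatter), a move toward stronger inhibition of growth, probably beyond the scatter but not large. Compound 4 is accordingly estimated in this assay at 30000 nM, within a range from 10000 nM to 90000 nM.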

Compound 4, concentration for 50% growth inhibition: 99000 nM
Compound 4: middle estimate off by 3.3-fold (0.52 log units), on the low side; measured number outside the range, above it.
By their numbers in this assay, from the lowest: compound 2; then compound 1; then compounds 3 and 4 (each within the scatter of the next).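

In this assay, putting hydroxy in place of (1H-1,2,4-triazol-5-yl)sulfanyl on a saturated chain carbon bound to a saturated ring carbon gives a 1.1-fold higher number from compound 3 to compound 4 (0.05 log units; within the scatter), so on this core the read-out does not tell the two groups apart, even though a whole five-membered aromatic ring and a sulfur atom leave and only an oxygen enters. This also weakens the earlier link between a hydroxy group at the chain end and the lowest number: the hydroxymethyl chain and nitrophenyl group are shared, and only the core differs, yet compound 2 gives 15000 nM while compound 4 gives 99000 nM, so hydroxy alone does not go with the lower number. Nothing measured here explains why the two groups read alike.

As far as these compounds go, it remains open whether other groups at this place, such as an amine, a carboxylic acid or a longer chain, would also leave the number where it stands. From the compounds shown here alone, it is equally open whether the same exchange would make so little difference on the core of compound 2.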